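Removing the nitrophenyl ether from compound 3: what to expect

The source may hold more compounds than are shown below. What is called first, only, known or untested is meant among the compounds shown, and "the series" means these compounds.

Compound 1, `Cc1ccccc1OCc1cn(-c2ccc(S(=O)(=O)N3CCc4ccccc4C3)cc2)nn1`: in a functional assay on MOLT-3 cells (Homo sapiens) for cytotoxicity, read by MTT assay, with a stated time of 48 h (a higher number here means a weaker inhibitor, a lower number a stronger inhibitor), compound 1 gives > 50 ug/mL, a limit of the assay.
Compound 2, `Cc1ccc(OCc2cn(-c3ccc(S(=O)(=O)N4CCc5ccccc5C4)cc3)nn2)cc1`: in this assay compound 2 gives > 50 ug/mL, also a limit.
Compound 3, `COc1cc2c(cc1OC)CN(S(=O)(=O)c1ccc(-n3cc(COc4ccc([N+](=O)[O-])cc4)nn3)cc1)CC2`: in this assay compound 3 gives > 50 ug/mL, again a limit.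

Compound 3 therefore stands where every measured compound stands: at the limit of > 50 ug/mL in this assay, at which 3 of the 3 values shown sit, with no number resolved for any of them. Within the data shown here, the one comparable step, a step that the two limits leave unreadable from compound 1 to compound 2, is unreadable for the same reason.

Compound 4, `COc1cc2c(cc1OC)CN(S(=O)(=O)c1ccc(-n3cc(CO)nn3)cc1)CC2`, differs from compound 3 by hydrogen in place of 4-nitrophenyl on an oxygen on a saturated carbon. Among the measured compounds shown here, no measured step speaks to this change, and the limits give no direction to read from. Compound 4 is expected to remain at the limit, so the estimated step that the limit leaves unreadable from compound 3 to compound 4 is none beyond the scatter. The estimate for compound 4 is 80 ug/mL, ranging from 30 ug/mL to 250 ug/mL.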

Compound 4, half-maximal inhibitory concentration: > 50 ug/mL
Compound 4 was reported as a limit; the forecaster's own chance of this, stated with the estimate: 85%; the middle value does not contradict the limit.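

No step can be read from compound 3 to compound 4, because both values are limits and not numbers: the limit of > 50 ug/mL in this assay, at which 4 of the 4 values shown sit.

The compounds shown leave open whether hydrogen in place of 4-nitrophenyl changes cytotoxicity at all, as none has a resolved number.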